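Swapping Methyl for Acetoxy on the Aromatic Ring

The source may report more compounds than this note shows. Statements on the series, on what has been measured and on what is new or still open speak of the compounds shown alone.

Of the compounds shown here, two sharing one core have been measured in a functional assay (muscle tissue) with Cavia porcellus as the target; a higher number here means that more compound is needed for the effect, a lower number that less compound is needed. Compound 1 `COC(=O)C1=C(C)N=C(C)/C(=C(\O)OC)C1c1cccc(N)c1` gives 2000 nM, while compound 2 `COC(=O)C1=C(C)N=C(C)/C(=C(\O)OC)C1c1cccc(C)c1` gives 110 nM, the lower of the two numbers. Compound 3 `COC(=O)C1=C(C)N=C(C)/C(=C(\O)OC)C1c1cccc(OC(C)=O)c1` has not yet been measured. It differs from compound 2 by one change, acetoxy in place of methyl on an aromatic carbon.

Within the data shown here, only one measured step bears on this change, and it concerns the same aromatic carbon. In that exchange of amino for methyl, the result is an 18-fold lower number from compound 1 to compound 2 (1.26 log units; beyond the scatter), a large step beyond the scatter. Among the measured compounds shown here, it shows that the group at this place can shift the number in this assay considerably, but no measured compound carries acetoxy, so its direction cannot be read directly from the data. A modest move toward a higher number is expected, and the uncertainty is wide. The expected change is a 2.3-fold higher number from compound 2 to compound 3 (0.36 log units; beyond the scatter). For compound 3 the estimate is 250 nM, with an expected range from 70 nM to 900 nM.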

Compound 3, half-maximal effective concentration: 6030 nM
Estimate against measurement, compound 3: 24-fold (1.38 log units) below, outside the stated range (above it).
By their numbers in this assay, from the lowest: compound 2; then compound 1; then compound 3.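

With acetoxy on this aromatic carbon, meta to a large group, this assay gives a 55-fold higher number from compound 2 to compound 3 (1.74 log units; beyond the scatter), so the methyl of compound 2 now stands apart from two different replacements rather than one. The acetoxy group also stands apart from the amino group, with a 3.0-fold higher number from compound 1 to compound 3 (0.48 log units; beyond the scatter), and this places compound 3 at the high end of the three compounds, whereas the earlier pair showed only that amino gave a higher number than methyl. Among these three compounds, then, both groups that differ from methyl at this place go with a higher number, and no compound shown goes against this, though nothing measured here explains the size of the rise with acetoxy.

The compounds shown leave open whether a group such as ethyl or methoxy at this carbon would keep the number close to that of compound 2 or move it toward that of compound 3. Going by these compounds, it also remains open whether a hydroxyl group or a carboxylic acid here would behave like acetoxy, and whether methyl would keep its lead at another carbon of the ring.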